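The source may hold more compounds than are shown below. What is called first, only, known or untested is meant among the compounds shown, and "the series" means these compounds.

Measured in a functional assay on the whole organism (Hindlimb, strain albino) with Mus musculus as the target, in the maximal electroshock model, with a stated time of 0.5 h; on this read-out lower numbers stand for an effect already at smaller amounts and higher numbers for an effect only at larger amounts of compound:
- compound 1 `COc1ccc(C2CC(Nc3nc4ccc(Cl)cc4s3)=NN2C(C)=O)cc1O`: 127 umol/kg
- compound 2 `COc1ccc(C2CC(Nc3nc4ccc([N+](=O)[O-])cc4s3)=NN2C(C)=O)cc1O`: 178 umol/kg
- compound 3 `COc1ccc(C2CC(Nc3nc4ccccc4s3)=NN2C(C)=O)cc1O`: 259 umol/kg

Compound 1 stands at the low end of these numbers. Going by the values given here, only the step of a 2.0-fold higher number from compound 1 to compound 3 (0.31 log units; beyond the scatter) clears the scatter, whereas a 1.4-fold higher number from compound 1 to compound 2 (0.15 log units; within the scatter) and a 1.5-fold higher number from compound 2 to compound 3 (0.16 log units; within the scatter) do not.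

Compound 4 `CC(=O)N1N=C(Nc2nc3ccc(Cl)cc3s2)CC1OC1=CC=C1` keeps the chloro group of compound 1 and differs elsewhere: a group of 5 heavy atoms (4 carbon, 1 oxygen; one four-membered non-aromatic ring of carbon only) in place of a group of 9 heavy atoms (7 carbon, 2 oxygen; one six-membered aromatic ring of carbon only), on a saturated ring carbon. All three measured steps exchange chloro, nitro or hydrogen on an aromatic carbon. None touches the saturated ring carbon, so they bear on this change only indirectly, by showing how narrow the numbers have been so far. The largest of them, a 2.0-fold higher number from compound 1 to compound 3 (0.31 log units; beyond the scatter), is modest. The data give no direction for the new change, so only a small move toward a higher number is expected, within the scatter and with wide uncertainty. The expected step is a 1.5-fold higher number from compound 1 to compound 4 (0.17 log units; within the scatter). For compound 4 the estimated value is 190 umol/kg, with an expected range of 70 umol/kg to 500 umol/kg.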

Compound 4, dose for half-maximal effect: 212 umol/kg
Estimate against measurement, compound 4: 1.1-fold (0.05 log units) below; low and high end bracket the measured number.
By their numbers in this assay, from the lowest: compounds 1, 2, 4 and 3 (each within the scatter of the next, the first and the last beyond it).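

Going by these compounds alone, the measured step (a 1.7-fold higher number from compound 1 to compound 4 (0.22 log units; within the scatter)) is the first reading at the saturated ring carbon, since the earlier steps only exchanged groups on an aromatic carbon. In this assay, with chloro kept, the 3-hydroxy-4-methoxyphenyl group, with its six-membered aromatic ring and its hydrogen-bond donor, can give way to a smaller group with a four-membered non-aromatic ring and no donor, and the number stays within the scatter of compound 1. Nothing at hand accounts for this tolerance, and a single pair cannot show how far it extends.

On these data alone, it remains open whether an amine, a carboxylic acid or a longer alkyl chain on this carbon would also stay within that range. As far as these compounds go, it is equally open whether the same exchange would read alike with nitro or hydrogen in place of chloro.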